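The source may hold more compounds than are shown below. What is called first, only, known or untested is meant among the compounds shown, and "the series" means these compounds.

Of the compounds shown here, three sharing one core have been tested in a functional assay on HOS cells (Homo sapiens) for antiproliferative activity, with a stated time of 72 h; a higher number here means a weaker inhibitor, a lower number a stronger inhibitor. Compound 1 `OC[C@H]1O[C@@H](n2cnc3c(NCc4ccc(F)cc4)ncnc32)[C@H](O)[C@@H]1O` gives a measured value of 13200 nM. Compound 2 `Cc1cccc(CNc2ncnc3c2ncn3[C@@H]2O[C@H](CO)[C@@H](O)[C@H]2O)c1` gives only a limit, > 166000 nM. Compound 3 `COc1ccccc1CNc1ncnc2c1ncn2[C@@H]1O[C@H](CO)[C@@H](O)[C@H]1O` also gives only a limit, > 166000 nM. Compound 3 thus sits at the limit of > 166000 nM in this assay, at which 2 of the 3 values shown sit, and it has no number of its own.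

Compound 4 `OC[C@H]1O[C@@H](n2cnc3c(NCc4ccc(F)cc4F)ncnc32)[C@H](O)[C@@H]1O` carries a 2,4-difluorophenyl in place of the 2-methoxyphenyl of compound 3, on a saturated chain carbon bound to a nitrogen on an aromatic ring: 2,4-difluorophenyl in place of 2-methoxyphenyl on a saturated chain carbon bound to a nitrogen on an aromatic ring. Going by the values given here, two measured steps bear on this change, and both are large: an at least 12-fold higher number from compound 1 to compound 3 (1.09 log units; beyond the scatter), and an at least 12-fold higher number from compound 1 to compound 2 (1.09 log units; beyond the scatter). The third, a step that the two limits leave unreadable from compound 2 to compound 3, adds nothing on size. Of the three compounds, only compound 1, with its fluorinated aryl group, gives a number, 13200 nM. The entering group also carries fluorine, so a large step to a lower number is expected, returning most of the way to compound 1. The effect of the second fluorine has not been tested, so the expectation stays loose, and another limit remains possible. The expected size of the change is an at least 6.6-fold lower number from compound 3 to compound 4 (0.82 log units; beyond the scatter). For compound 4 the estimated value in this assay is 25000 nM, within an expected range of 6000 nM to 120000 nM.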

Compound 4, half-maximal inhibitory concentration: > 166000 nM
Compound 4: only a limit was reported (the forecaster's own chance of this, stated with the estimate: 25%); middle value at least 6.6-fold (0.82 log units) from the limit.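

In this assay, a single fluoro in place of hydrogen on an aromatic carbon is a large change: the result is an at least 12-fold higher number from compound 1 to compound 4 (1.09 log units; beyond the scatter). A fluorine on the aryl group is therefore not enough to keep a measurable value, and compound 4 goes against any pattern linking fluorine to a number, leaving the 4-fluorophenyl of compound 1 as the only group shown that gives one. Compound 4 reaches only a limit, so the steps to it from compound 2 and compound 3 cannot be read, and 2,4-difluorophenyl cannot be ranked against 3-methylphenyl or 2-methoxyphenyl: the limit of > 166000 nM in this assay, at which 3 of the 4 values shown sit.

The compounds shown leave open how far compounds 2, 3 and 4 lie past that limit, and why the added fluorine costs the measurable value, which these data cannot tell. They also leave open whether a plain phenyl, a 4-chlorophenyl or a 4-methoxyphenyl on the same saturated chain carbon would give a number like that of compound 1.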